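The compounds below may be only part of what the source reports. "The series", "measured", "known", "first", "only" and "open" are said of these compounds alone.

Of the compounds shown here, three of a shared core have so far been measured in an in vitro assay on HEK-tsA201 cells for antagonist activity at Neuronal acetylcholine receptor; alpha3/beta4 (Homo sapiens), read by fluorescence and calcium flux; on this read-out lower numbers stand for stronger inhibition and higher numbers for weaker inhibition. Compound 1 `C=C(C)COc1ccc(C(=O)Nc2cccc(C)n2)cc1` gives 24700 nM, compound 2 `C#CCOc1ccc(C(=O)Nc2cccc(C)n2)cc1` gives 21700 nM, and compound 3 `CCCOc1ccc(C(=O)Nc2cccc(CC)n2)cc1` gives 29200 nM. The numbers for compound 3, compound 1 and compound 2 lie within the usual scatter of one another, so none of them can be set apart from the rest. Within the data shown here, the one step among them that changes a single place is a 1.1-fold lower number from compound 1 to compound 2 (0.06 log units; within the scatter), a change on the chain attached to the oxygen, which left the number essentially where it was.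

Compound 4 `CCCOc1ccc(C(=O)Nc2cccc(N3CCCCC3)n2)cc1` has not yet been measured. It differs from compound 3 in one place: piperidin-1-yl in place of ethyl on an aromatic carbon. Among the measured compounds shown here, no measured step touches this position on the ring with one nitrogen, so the only comparison available is the single step on the oxygen-bound chain, which was within the scatter. There is therefore no basis in the measured compounds for expecting a move in either direction beyond the scatter, and the estimate for compound 4 is accordingly set close to compound 3, at a 1.3-fold lower number from compound 3 to compound 4 (0.12 log units; within the scatter). Compound 4 is thus expected to give about 22000 nM in this assay, within a range from 6000 nM to 80000 nM.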

Compound 4, half-maximal inhibitory concentration: > 100000 nM
Compound 4: no number, only a limit (the forecaster's own chance of this, stated with the estimate: 25%); at least 4.5-fold (0.65 log units) between middle value and limit.
By their numbers in this assay, from the lowest: compounds 2, 1 and 3 (each within the scatter of the next). At a limit, above all of these: compound 4.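

This is the only step shown that moves the number beyond the scatter (an at least 3.4-fold higher number from compound 3 to compound 4 (0.53 log units; beyond the scatter)), and it falls on the aromatic carbon next to the ring nitrogen, a place that no earlier step touched. The position therefore does respond to what sits on it, and in this pair the response is weaker inhibition when piperidin-1-yl, a six-membered non-aromatic ring with 1 hydrogen-bond acceptor, takes the place of ethyl, although this single pair cannot say which feature of the new group matters. For compound 4 the entry in this assay is a limit and not a number (> 100000 nM), so the full size of the step cannot be read: (the limit of > 100000 nM in this assay, at which 1 of the 4 values shown sits).

On these data alone, it remains open whether a smaller group at this place, such as an open-chain dimethylamino group, a methoxy group or a five-membered pyrrolidine ring, would keep the number near that of compound 3 or lose inhibition as well. Piperidin-1-yl also appears with only one chain on the oxygen, and whether it behaves the same way with the other chains is not shown.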